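Following a side-chain swap from compound 3 to compound 4

This account rests on a few compounds, and the source may have more. Where it says the series, first, only, none or still open, it means among the compounds named here.

In a physicochemical assay for solubility, in phosphate buffer, measured as thermodynamic solubility, at pH 2 (on this read-out lower numbers stand for lower solubility and higher numbers for higher solubility), compound 1 (`CC(C)(C)OC(=O)N1CCCC(Nc2nc3c(c(Nc4ccc(C(F)(F)F)cc4)n2)CCN(c2ncccc2C(F)(F)F)CC3)C1`) gives 1 ug/mL. Compound 2 (`CN(c1nc2c(c(Nc3ccc(C(F)(F)F)cc3)n1)CCN(c1ncccc1C(F)(F)F)CC2)C1CCCNC1`) reads > 241 ug/mL, which is a limit of the assay and not a number. Compound 3 (`FC(F)(F)c1ccc(Nc2nc(N3CCN(C4CCC4)CC3)nc3c2CCN(c2ncccc2C(F)(F)F)CC3)cc1`) reads > 237 ug/mL, and this too is only a limit, so it marks no exact starting point.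

Compound 4 (`CNC1CCN(c2nc3c(c(Nc4ccc(C(F)(F)F)cc4)n2)CCN(c2ncccc2C(F)(F)F)CC3)C1`) keeps the core of compound 3 but carries 3-(methylamino)pyrrolidin-1-yl in place of 4-cyclobutylpiperazin-1-yl on an aromatic carbon, between two ring nitrogen atoms: 3-(methylamino)pyrrolidin-1-yl in place of 4-cyclobutylpiperazin-1-yl on an aromatic carbon.

Among the compounds with values here, the only measured step that bears on this swap is a step that the two limits leave unreadable from compound 2 to compound 3, and it offers no size to carry forward. It concerns the same position, and neither of its two compounds falls to a readable number in this assay. On that slim basis, compound 4 is expected to stay in the same region, and its reading may again be only a limit. The expected change is a step that the limit leaves unreadable from compound 3 to compound 4. For compound 4 the estimated solubility is 240 ug/mL, within an expected range of 90 ug/mL to 500 ug/mL.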

Compound 4, solubility: > 220 ug/mL
Compound 4: only a limit was reported; the forecaster's own chance of this, stated with the estimate: 75%; the middle value is on the limit's open side.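

In this assay compound 4 gives > 220 ug/mL, which is a limit and not a number. The steps from compound 3 to compound 4 and from compound 2 to compound 4 cannot be read, since all three carry only limits. The compounds shown leave open how far the solubilities of compound 2, compound 3 and compound 4 actually differ.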